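This account rests on a few compounds, and the source may have more. Where it says the series, first, only, none or still open, it means among the compounds named here.

Measured compounds:
compound 1, `CC(=O)Nc1cccc(Cn2cc(-c3ccc4c(N)n[nH]c4c3)ccc2=O)c1` — 8 nM
compound 2, `O=c1ccc(-c2ccc3cn[nH]c3c2)cn1Cc1cccc(Cl)c1` — 40 nM
compound 3, `CC(=O)Nc1cccc(Cn2cc(-c3ccc4cn[nH]c4c3)ccc2=O)c1` — 43 nM

Of the compounds shown here, three built on a shared core have been tested in an assay for inhibition of MAP kinase-interacting serine/threonine-protein kinase 2 (Homo sapiens), read by luminescence and ADP-Glo, with a stated time of 2 h; on this read-out higher numbers stand for weaker inhibition and lower numbers for stronger inhibition. Compound 3 stands apart from compound 1 by a 5.4-fold higher number from compound 1 to compound 3 (0.73 log units; beyond the scatter), a modest step that comes from hydrogen in place of amino on an aromatic carbon. Toward compound 2 the gap is different in kind: a 1.1-fold higher number from compound 2 to compound 3 (0.03 log units; within the scatter) lies within the scatter, so acetamido in place of chloro on an aromatic carbon has left the number essentially unmoved.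

Compound 4, `Nc1cccc(Cn2cc(-c3ccc4cn[nH]c4c3)ccc2=O)c1`, has not yet been measured. It differs from compound 3 in one place, (hydrogen in place of acetyl on a nitrogen on an aromatic ring). Going by the values given here, the only measured step that touches this part of the molecule is the one from compound 2 to compound 3, and that step was within the scatter. The core of compound 3, with its hydrogen where compound 1 carries amino, is untouched in compound 4, so the step from compound 1 to compound 3 gives no guidance here. On this evidence, no step beyond the scatter is expected in this assay in either direction, so compound 4 is expected to give a 1.1-fold lower number from compound 3 to compound 4 (0.03 log units; within the scatter). Compound 4 is therefore estimated at 40 nM, with a range from 15 nM to 120 nM.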

Compound 4, half-maximal inhibitory concentration: 84 nM
Compound 4: middle estimate off by 2.1-fold (0.32 log units), on the low side; low and high end bracket the measured number.
By their numbers in this assay, from the lowest: compound 1; then compounds 2, 3 and 4 (each within the scatter of the next, the first and the last beyond it).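

In this assay, hydrogen in place of acetyl on a nitrogen on an aromatic ring gives a 2.0-fold higher number from compound 3 to compound 4 (0.29 log units; within the scatter), so the acetyl on this nitrogen is not shown to matter, although this step reaches the edge of the scatter. Going by these compounds alone, the comparison with chloro gives the first step at this aromatic carbon that can be read as a real difference: amino in place of chloro gives a 2.1-fold higher number from compound 2 to compound 4 (0.32 log units; beyond the scatter), a modest step, whereas acetamido in place of chloro gave only a 1.1-fold higher number from compound 2 to compound 3 (0.03 log units; within the scatter). The three groups therefore do not fall into clearly separate levels, since only chloro and amino lie beyond the scatter of each other, and nothing available here explains the difference between them.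

As far as these compounds go, what a carboxylic acid, a methanesulfonamide or a dimethylamino group on this aromatic carbon would give remains open, so three groups cannot yet show a trend at this place. From the compounds shown here alone, it is also open whether amino on this aromatic carbon would give a similar step on the core of compound 1, where the amino on the shared core accounts for a 5.4-fold higher number from compound 1 to compound 3 (0.73 log units; beyond the scatter).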